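Amide variation on the series of compound 2

The source may hold more compounds than are shown below. What is called first, only, known or untested is meant among the compounds shown, and "the series" means these compounds.

Three compounds have numbers in a functional assay on HCT-116 cells (Homo sapiens) for inhibition, read by MTT assay, with a stated time of 48 h; on this read-out higher numbers stand for weaker inhibition and lower numbers for stronger inhibition. Compound 1 `COc1ccc(CNc2cc(OC)c(OC)c(OC)c2)cc1Cl` gives 41700 nM in this assay. Compound 3 `COc1ccc(N(Cc2cc(OC)c(OC)c(OC)c2)C(=O)CCl)cc1O` gives 22500 nM in this assay. Compound 2 `C=C(C)C(=O)N(Cc1ccc(OC)c(O)c1)c1cc(OC)c(OC)c(OC)c1` gives 200 nM in this assay, the lowest of the three numbers; its nearest neighbour is compound 3, whose number is higher by a margin beyond the scatter, and compound 1 stands furthest from it, also beyond the scatter. Among the compounds with values here, no two of the measured compounds differ in only one place, so no single-point step is available from them.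

Compound 4 `C/C=C/C(=O)N(Cc1ccc(OC)c(O)c1)c1cc(OC)c(OC)c(OC)c1` has not yet been measured in this assay. It differs from compound 2 as follows: prop-1-en-1-yl in place of 1-methylethenyl on a carbonyl carbon. The two compounds share all atoms and differ only in how the three-carbon group on the carbonyl carbon is joined. Within the data shown here, nothing among the measured compounds isolates this change. The step is expected to be small, within or near the scatter, with a slight lean toward a higher number; the estimated step of a 2.0-fold higher number from compound 2 to compound 4 (0.30 log units; within the scatter) reflects this. Compound 4 is expected to give about 400 nM in this assay, with a range from 100 nM to 2000 nM.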

Compound 4, half-maximal inhibitory concentration: 55 nM
Beside the measured number, compound 4's estimate is 7.3-fold (0.86 log units) above it; the measured number lies below the stated range.
By their numbers in this assay, from the lowest: compound 4; then compound 2; then compounds 3 and 1 (each within the scatter of the next).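

In this assay the change from 1-methylethenyl to prop-1-en-1-yl on a carbonyl carbon gives a 3.6-fold lower number from compound 2 to compound 4 (0.56 log units; beyond the scatter) and so shows that this position responds to how the three-carbon group is joined, even though the atoms stay the same. Within the data shown here, this is the only single-point step available, as the other measured compounds differ from one another in more than one place. No measurement at hand accounts for the step.

From the compounds shown here alone, whether the lower number is specific to prop-1-en-1-yl remains open, as a saturated propyl group, a plain ethenyl group and a longer chain such as pent-1-en-1-yl have no numbers on this carbonyl carbon. Going by these compounds, it is also open whether the same change would give a step of similar size on the core of compound 3.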